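The source may hold more compounds than are shown below. What is called first, only, known or untested is meant among the compounds shown, and "the series" means these compounds.

Compounds measured: compound 1 `O=S(=O)(c1cccc(C(F)(F)F)c1)c1cn(C2CCNC2)c2ncccc12` with 1.3 nM; compound 2 `CN1CCC(n2cc(S(=O)(=O)c3ccccc3)c3cccnc32)C1` with 2.5 nM.

In an assay on HeLa cells for displacement of a labelled ligand from 5-hydroxytryptamine receptor 6 (Homo sapiens) (on this read-out lower numbers stand for stronger inhibition and higher numbers for weaker inhibition), compound 2 and compound 1 stand within the usual scatter of each other, so the two numbers cannot be told apart. Compound 3 `CN1CCC(n2cc(S(=O)(=O)c3ccc(Cl)cc3)c3cccnc32)C1` is not yet measured; it differs from compound 2 in one place: chloro in place of hydrogen on an aromatic carbon. Within the data shown here, no measured pair shows the same change, so the size of the step has to be guessed. He expects the step of a 1.3-fold lower number from compound 2 to compound 3 (0.10 log units; within the scatter) to stay within the scatter or to bring a small gain, nothing larger. For compound 3 he estimates 2 nM, with a range from 0.7 nM to 6 nM.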

Compound 3, inhibition constant: 4.2 nM
The estimate for compound 3 lay 2.1-fold (0.32 log units) below the measured number; low and high end bracket the measured number.
By their numbers in this assay, from the lowest: compounds 1, 2 and 3 (each within the scatter of the next, the first and the last beyond it).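

In this assay, the 4-chlorophenyl group of compound 3 replaces the phenyl group of compound 2 with a 1.7-fold higher number from compound 2 to compound 3 (0.23 log units; within the scatter), so a chlorine on this aromatic carbon, para to a large group, leaves the two compounds indistinguishable. Among these compounds, this is the first single-place comparison, and it shows that this position accepts chloro without a step beyond the scatter. No measurement shown here speaks to the reason for this result. On these data alone, it remains open whether a larger change at this position, such as an amine, a methoxy group or a carboxylic acid, would move the number beyond the scatter.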